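Series notes: methoxy in place of phenyl, compound 3

The source may hold more compounds than are shown below. What is called first, only, known or untested is meant among the compounds shown, and "the series" means these compounds.

Two compounds of the series carry numbers in an assay on mitochondria (strain BALB/c) for inhibition of glycerol-3-phosphate acyltransferase 1, mitochondrial (Mus musculus), read by scintillation counting, with a stated time of 10 min; a higher number here means a weaker inhibitor, a lower number a stronger inhibitor. Compound 1 `CCCCCCCCS(=O)(=O)Nc1ccc(-c2cccc(Cl)c2)cc1C(=O)O` gives 8900 nM in this assay. Compound 2 `CCCCCCCCS(=O)(=O)Nc1ccc(C(=O)c2ccc(-c3ccccc3)cc2)cc1C(=O)O` gives 13000 nM in this assay, the highest of the two numbers, with compound 1 as its nearest neighbour at a gap that lies within the scatter; the two values show no order between them.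

Compound 3 `CCCCCCCCS(=O)(=O)Nc1ccc(C(=O)c2ccc(OC)cc2)cc1C(=O)O` has not been measured. It differs from compound 2 in one place: methoxy in place of phenyl on an aromatic carbon. Among the measured compounds shown here, no step between measured compounds maps onto this change, so no measured step guides the expectation. With both measured numbers lying close together, the expected step from compound 2 to compound 3 is none beyond the scatter, estimated as a 1.2-fold higher number from compound 2 to compound 3 (0.06 log units; within the scatter). Compound 3 is expected to give 15000 nM in this assay, with an estimated range from 6000 nM to 40000 nM.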

Compound 3, half-maximal inhibitory concentration: 44300 nM
Compound 3: middle estimate off by 3.0-fold (0.47 log units), on the low side, outside the stated range (above it).
By their numbers in this assay, from the lowest: compounds 1 and 2 (each within the scatter of the next); then compound 3.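

Among the compounds shown here, on the aromatic carbon para to a large group, the substituent now matters in this assay: methoxy in place of phenyl gives a 3.4-fold higher number from compound 2 to compound 3 (0.53 log units; beyond the scatter), the first step beyond the scatter. (4-Methoxyphenyl)carbonyl in place of 3-chlorophenyl gives a 5.0-fold higher number from compound 1 to compound 3 (0.70 log units; beyond the scatter), which leaves compound 3 as the weakest inhibitor of the three. Nothing measured on these compounds accounts for either step.

The compounds shown do not separate the loss of the phenyl ring from the arrival of the methoxy oxygen. As far as these compounds go, a methyl, a chlorine or a benzyloxy group on the same carbon would bear on that question, and whether any group there could give a lower number than phenyl remains open.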